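Chain-shortened iodoacetamide nucleotide analogues against hexokinase-2

A few compounds are considered here, and "the series" means these few. Any claim that something is new, unique, unknown or untested is made for them only; others in the source may bear on it.

Measured compounds:
compound 1 `O=C(CI)NCCCCC(=O)NCCCCCCNc1ncnc2c1ncn2[C@@H]1O[C@H](COP(=O)(O)OP(=O)(O)OP(=O)(O)O)[C@@H](O)[C@H]1O` — 0%
compound 2 `O=C(CI)NCCCCCCC(=O)NCCCCCCNc1ncnc2c1ncn2[C@@H]1O[C@H](COP(=O)(O)OP(=O)(O)OP(=O)(O)O)[C@@H](O)[C@H]1O` — 0%
compound 3 `O=C(CI)NCCCCNc1ncnc2c1ncn2[C@@H]1O[C@H](COP(=O)(O)OP(=O)(O)OP(=O)(O)O)[C@@H](O)[C@H]1O` — 0%

Three compounds carry the same nucleotide part and an iodoacetamide on a linker of varying length. In an assay on isolated protein for inhibition of hexokinase-2 (Rattus norvegicus), with a stated time of 6 h, tested at 10 mM (on this read-out lower numbers stand for less inhibition and higher numbers for more inhibition at the one concentration tested (going by the name of the read-out)), compound 1 gives 0%, compound 2 gives 0% and compound 3 gives 0%. Shortening the linker, (((iodomethyl)carbonyl)amino in place of 2-(((iodomethyl)carbonyl)amino)ethyl on a saturated chain carbon, four bonds along the chain from a carbonyl carbon), gives no change at the digits printed from compound 2 to compound 1 (within the scatter). Compound 3 stands level with both at the digits printed; how its core differs from that of compound 2 is not broken down here.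

Compound 4 `O=C(CI)NCCNc1ncnc2c1ncn2[C@@H]1O[C@H](COP(=O)(O)OP(=O)(O)OP(=O)(O)O)[C@@H](O)[C@H]1O` has not yet been measured. It arises from compound 3 by ((iodomethyl)carbonyl)amino in place of 2-(((iodomethyl)carbonyl)amino)ethyl on a saturated chain carbon, two bonds along the chain from a nitrogen on an aromatic ring. This is the same kind of change as that from compound 2 to compound 1, but not the same: there the change sat four bonds along the chain from a carbonyl carbon, here it sits two bonds along the chain from a nitrogen on an aromatic ring.

Because the earlier step reads no change at the digits printed from compound 2 to compound 1 (within the scatter), and because compound 3 itself reads 0%, the expected step is no change at the digits printed from compound 3 to compound 4 (within the scatter) in this assay. Compound 4 is estimated at 0%, expected between 0% and 10%.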

Compound 4, a percentage reported as inhibition, at one concentration (the size of the read-out at that concentration, not a potency): 0%
Compound 4: the middle estimate sits on the measured number at the digits printed; the range from low to high includes it.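

In this assay, ((iodomethyl)carbonyl)amino in place of 2-(((iodomethyl)carbonyl)amino)ethyl gives no change at the digits printed from compound 3 to compound 4 (within the scatter). Set beside the earlier step, the change reads alike on the two cores: the same change on two cores in this assay, no change at the digits printed (within the scatter) from compound 2 to compound 1 and no change at the digits printed (within the scatter) from compound 3 to compound 4, 0 percentage points apart, within the scatter of two such steps This agreement is thin evidence for transfer, since every step starts and ends with no inhibition on this read-out, as with compound 4 at 0%, so it shows only that shortening brings out no inhibition on either core, not that the change would be neutral on a compound with measurable inhibition.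

Open, from the compounds shown here alone, is whether any inhibition appears in this assay with a chain longer than that of compound 2, or with another group at the chain end, such as an acrylamide or a free amine, in place of the ((iodomethyl)carbonyl)amino group. Also open, going by these compounds, is whether a change in the nucleotide part, such as a diphosphate in place of the triphosphate, would give a reading from which a step in chain length could be judged.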